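The compounds below may be only part of what the source reports. "The series", "measured", "known", "first", "only" and "open" are said of these compounds alone.

The series rests on one shared core, carried by compound 1 `CCCCC#Cc1cn(C/C=C\CN2C(=O)c3ccccc3C2=O)c(=O)[nH]c1=O`, compound 2 `O=C1c2ccccc2C(=O)N1C/C=C\Cn1cc(C#CCCc2ccccc2)c(=O)[nH]c1=O`, compound 3 `O=C1c2ccccc2C(=O)N1C/C=C/Cn1cc(C#CCCc2ccccc2)c(=O)[nH]c1=O` and the not yet measured compound 4 `CCCCC#Cc1cn(C/C=C/CN2C(=O)c3ccccc3C2=O)c(=O)[nH]c1=O`. In a functional assay on HepG2 cells (Homo sapiens) for antiproliferative activity, read by MTT assay, with a stated time of 3 days (a higher number here means a weaker inhibitor, a lower number a stronger inhibitor), compound 1 gives 17000 nM. Compound 2 reaches only a limit of the assay in this assay, > 100000 nM. Compound 3 gives 7300 nM in this assay, the lowest number among the measured compounds. Compound 2 and compound 3 differ in that (the two compounds have the same atoms and bonds and differ only in configuration as drawn: 1 of 1 stereo elements differ; a double bond is drawn Z in compound 2 and E in compound 3), and this gave an at least 13-fold lower number from compound 2 to compound 3 (1.13 log units; beyond the scatter); the step can be read only as a bound because of the limit of > 100000 nM in this assay, at which 1 of the 3 values shown sits. The change ethyl in place of phenyl on a saturated chain carbon, two bonds along the chain from a triple-bonded carbon gave an at least 5.8-fold lower number from compound 2 to compound 1 (0.76 log units; beyond the scatter), again a bound because of the limit of > 100000 nM in this assay, at which 1 of the 3 values shown sits. Compound 4 differs from compound 3 by the same change, (ethyl in place of phenyl on a saturated chain carbon, two bonds along the chain from a triple-bonded carbon). In this assay the step of a 2.4-fold lower number from compound 3 to compound 4 (0.39 log units; beyond the scatter) is expected, resting on the earlier step of an at least 5.8-fold lower number from compound 2 to compound 1 (0.76 log units; beyond the scatter), which was seen in the other drawn configuration. Compound 4 is therefore estimated at 3000 nM, between 800 nM and 10000 nM.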

Compound 4, half-maximal inhibitory concentration: 7900 nM
The estimate for compound 4 lay 2.6-fold (0.42 log units) below the measured number; low and high end bracket the measured number.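

In this assay, the same replacement of phenyl by ethyl gave a 1.1-fold higher number from compound 3 to compound 4 (0.03 log units; within the scatter), so the lower number seen with this change on the core drawn Z did not carry over to the core drawn E: the same change on two cores in this assay, an at least 5.8-fold lower number (0.76 log units; beyond the scatter) from compound 2 to compound 1 and a 1.1-fold higher number (0.03 log units; within the scatter) from compound 3 to compound 4, at least 6.3-fold (0.80 log units) apart, beyond the scatter of two such steps The double-bond configuration also changed the number with the hex-1-yn-1-yl chain, where the step was a 2.2-fold lower number from compound 1 to compound 4 (0.33 log units; beyond the scatter): the fact that compounds 1 and 4 differ only in the configuration as drawn The result shows that, in these two pairs, the outcome of the change depended on the drawn configuration, but it does not show why, and the earlier step remains only a bound, with its true size and the true gap between the two steps unknown: the limit of > 100000 nM in this assay, at which 1 of the 4 values shown sits.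

The compounds shown leave open how an amine, a hydroxyl or a longer chain in place of the ethyl would behave in either configuration. They also leave open whether this dependence on configuration extends beyond these two pairs.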